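This account rests on a few compounds, and the source may have more. Where it says the series, first, only, none or still open, it means among the compounds named here.

Measured so far in a functional assay on KBVIN cells (Homo sapiens) for cytotoxicity, read by MTT assay, with a stated time of 72 h; a lower number here means that less compound is needed, a higher number that more compound is needed for the effect:
compound 1 `CCc1cccc2c(OC)c(-c3occ(C)c3C(=S)OC)ccc12` gives 5.1 ug/mL;
compound 2 `CCOc1c(-c2occ(C)c2C(=O)OC)ccc2c(CC)cccc12` gives 1.7 ug/mL;
compound 3 `CCOc1c(-c2occ(C)c2CO)ccc2c(CC)cccc12` gives 6.4 ug/mL.

Among these three numbers, compound 1 stands second highest. The values of compound 1 and compound 3 lie within the scatter of each other, so nothing separates them; compound 2 gives a lower number than compound 1, and that gap lies beyond the scatter.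

Compound 4 `CCOCc1c(C)coc1-c1ccc2c(CC)cccc2c1OC` has not yet been measured. It differs from compound 1 in one place: a group of 4 heavy atoms (3 carbon, 1 oxygen; no ring) in place of a group of 4 heavy atoms (2 carbon, 1 oxygen, 1 sulfur; no ring), on an aromatic carbon. One measured step resembles this change, since there too a methoxycarbonyl was exchanged for a hydroxymethyl, a group in which the ring carbon carries oxygen through a saturated carbon: a 3.8-fold higher number from compound 2 to compound 3 (0.58 log units; beyond the scatter). On that basis, a modest rise in the number is expected in this assay, with the step from compound 1 to compound 4 estimated as a 2.2-fold higher number from compound 1 to compound 4 (0.33 log units; beyond the scatter). Compound 4 is therefore expected to give about 11 ug/mL in this assay, within a range from 4.5 ug/mL to 28 ug/mL.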

Compound 4, concentration for half-maximal effect: > 10 ug/mL
Compound 4 ended at the assay's limit (the forecaster's own chance of this, stated with the estimate: 5%); the middle value is on the limit's open side.
By their numbers in this assay, from the lowest: compound 2; then compounds 1 and 3 (each within the scatter of the next). At a limit, above all of these: compound 4.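

In this assay compound 4 gives > 10 ug/mL, which is a limit of the assay and not a number: the limit of > 10 ug/mL in this assay, at which 1 of the 4 values shown sits. With ethoxymethyl at this place on the five-membered ring, in place of the sulfur-bearing group of compound 1, the step reads an at least 1.9-fold higher number from compound 1 to compound 4 (0.29 log units; that floor lies within the scatter), so only a floor is known and that floor alone does not separate the two compounds. Even so, it gives the first reading at this place for a group that joins oxygen to the ring through a saturated carbon as an ether, and nothing in it points to a lower number than that of compound 1.

As far as these compounds go, how far compound 4 lies past the limit stays open, as does whether an amine, a carboxylic acid or an amide at this place would give a lower number than the methoxycarbonyl of compound 2. Ethoxymethyl also appears on only one core here, so its effect on the ethoxy-bearing core of compound 2 remains unknown.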